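Dichloroacetanilides: nitro in place of chloro, weak antiproliferatives

The source may hold more compounds than are shown below. What is called first, only, known or untested is meant among the compounds shown, and "the series" means these compounds.

Working notes on a small set of dichloroacetanilides tested in a functional assay on KB cells (Homo sapiens) for antiproliferative activity, read by MTT assay, with a stated time of 72 h; a lower number here means a stronger inhibitor, a higher number a weaker inhibitor. Compound 1 `O=C(Nc1ccccc1F)C(Cl)Cl` carries a fluoro substituent and gives "not determined" (no result reported) in this assay, so no number stands against it. Among the measured compounds shown here, compound 2 `O=C(Nc1ccccc1[N+](=O)[O-])C(Cl)Cl` carries a nitro group and gives 253000 nM in this assay, the only single number in the set and a weak one. Compound 3 `O=C(Nc1cccc(Cl)c1)C(Cl)Cl` carries a chloro substituent and also gives "not determined" (no result reported) in this assay; it therefore stands without a number, and one further entry of the set is likewise without one. For the measured compounds named here, no two measured compounds differ in only one place, so no step between measured values can be drawn.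

Compound 4 `O=C(Nc1cccc([N+](=O)[O-])c1)C(Cl)Cl` is the next entry. It differs from compound 3 by nitro in place of chloro on an aromatic carbon. Going by the values given here, with compound 3 lacking a number, no step size can be computed; the only anchor is compound 2 with 253000 nM, and compound 4 as a second nitro analogue is expected to fall in the same weak region, within the scatter of that value rather than clearly stronger or weaker. Compound 4 is accordingly estimated at 200000 nM, with a range from 60000 nM to 600000 nM.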

Compound 4, half-maximal inhibitory concentration: 44700 nM
Beside the measured number, compound 4's estimate is 4.5-fold (0.65 log units) above it; the measured number lies below the stated range.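

Among the compounds shown here, compound 3 has no single number in this assay, so no step from it to compound 4 can be read. The compounds shown leave open what nitro in place of chloro on the aromatic carbon does to antiproliferative activity. No supporting data bear on the result for compound 4.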